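The source may hold more compounds than are shown below. What is called first, only, known or untested is meant among the compounds shown, and "the series" means these compounds.

Series notes. Compound 1 `O=C1CC(c2nc(-c3cccc(Cl)c3)no2)CN1c1cccc(Cl)c1` carries two chlorophenyl groups around the shared core; in an in vitro functional assay on HEK293-A cells for positive allosteric modulation of metabotropic glutamate receptor 5 (Homo sapiens), read by FLIPR and calcium flux (a lower number here means that less compound is needed, a higher number that more compound is needed for the effect), compound 1 gives only a limit, > 10000 nM. This is the limit at which two of the three values shown sit, (the limit of > 10000 nM in this assay, at which 2 of the 3 values shown sit). Compound 3 `O=c1sc2ccccc2n1Cc1nc(-c2cccc(Cl)c2)no1`, built on a different core, also returns only a limit in this assay, > 10000 nM. Going by the values given here, compound 2 `COc1cccc(-c2noc(C3CC(=O)N(c4ccc(F)cc4)C3)n2)c1` is the one measured compound that gives a number in this assay, 1100 nM.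

Compound 4 `COc1cccc(N2CC(c3nc(-c4cccc(Cl)c4)no3)CC2=O)c1` is not yet measured. It differs from compound 1 as follows: methoxy in place of chloro on an aromatic carbon. Among the measured compounds no step that differs in one place is available to size the effect of methoxy in place of chloro, and the values of compound 2 and compound 1 cannot be attributed to any single change. For compound 4 the step from compound 1 is expected to be an at least 1.2-fold lower number from compound 1 to compound 4 (0.09 log units; that floor lies within the scatter), toward lower numbers if anything, with a fair chance that only a limit is reported again. Compound 4 is estimated at 8000 nM, in the range 2000 nM to 30000 nM.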

Compound 4, half-maximal effective concentration: > 10000 nM
Compound 4: a limit, no number; the forecaster's own chance of this, stated with the estimate: 55%; middle value at least 1.2-fold (0.09 log units) away from the limit.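

Compound 4 returns only a limit in this assay, > 10000 nM. Going by these compounds alone, compound 1 also stands at a limit, so no step between compound 1 and compound 4 can be read. The compounds shown leave open what size of effect, if any, methoxy in place of chloro has.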